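Methyl for Methoxy on the Core of Compound 3

The compounds below may be only part of what the source reports. "The series", "measured", "known", "first", "only" and "open" are said of these compounds alone.

Of the compounds shown here, three share one core and have been tested in an assay on isolated protein for displacement of a labelled ligand from metabotropic glutamate receptor 5 (Homo sapiens), with a stated time of 60 min, tested at 1 uM; a higher number here means more inhibition at the concentration tested (going by the name of the read-out), a lower number less inhibition. Compound 1, `COc1ccc(S(=O)(=O)c2cnc3ccc(C)cc3c2N2CCC(C)CC2)cc1`, gives 62%. Compound 2, `Cc1ccc(S(=O)(=O)c2cnc3ccc(C)cc3c2N2CCC(C)CC2)cc1`, gives 82%. Compound 3, `COc1ccc2ncc(S(=O)(=O)c3ccc(C)c(F)c3)c(N3CCC(C)CC3)c2c1`, gives 73%, which places it second highest of the three: its value and that of compound 2 lie within the scatter of each other, while it sits above compound 1 by a gap beyond the scatter.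

Compound 4, `Cc1ccc2ncc(S(=O)(=O)c3ccc(C)c(F)c3)c(N3CCC(C)CC3)c2c1`, has not yet been measured. It differs from compound 3 in one place: methyl in place of methoxy on an aromatic carbon. The same kind of change, a methyl in place of a methoxy on an aromatic carbon, has been seen once already, although on a different ring of the molecule, where it gave a number 20 percentage points higher from compound 1 to compound 2 (beyond the scatter). Within the data shown here, no other measured step bears on it.

On that single precedent, the step from compound 3 to compound 4 is expected to be upward, and the estimate is a number 9 percentage points higher from compound 3 to compound 4 (within the scatter) in this assay. Because compound 2 already gives 82%, a rise of similar size would bring compound 4 close to the highest value seen so far, so compound 4 is estimated at 82%, with a range from 68% to 94%.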

Compound 4, a percentage reported as inhibition, at one concentration (the size of the read-out at that concentration, not a potency): 91%
Estimate against measurement, compound 4: 9 percentage points below; measured number inside the range.
By their numbers in this assay, from the lowest: compound 1; then compounds 3, 2 and 4 (each within the scatter of the next, the first and the last beyond it).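

Methyl in place of methoxy on an aromatic carbon had so far been seen on one ring only, and it now gives a number 18 percentage points higher from compound 3 to compound 4 (beyond the scatter) in this assay on a six-membered aromatic ring of carbon only, part of a fused or bridged system of two rings. The size of the gain carries over closely from one core to the other: the same change on two cores in this assay, a number 20 percentage points higher (beyond the scatter) from compound 1 to compound 2 and a number 18 percentage points higher (beyond the scatter) from compound 3 to compound 4, 2 percentage points apart, within the scatter of two such steps Fluoro in place of hydrogen on an aromatic carbon gives a number 9 percentage points higher from compound 2 to compound 4 (within the scatter), so that single atom makes no clear difference here, while 3-fluoro-4-methylphenyl in place of 4-methoxyphenyl on a sulfonyl sulfur gives a number 29 percentage points higher from compound 1 to compound 4 (beyond the scatter), a step that includes the first methyl-for-methoxy change.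

The compounds shown leave open whether the gain belongs to methyl itself or would also appear with another group on that carbon, such as ethyl, chloro or a nitrile. Since this assay reads inhibition at a single concentration, these numbers also leave open how far the compounds differ in potency.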